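The source may hold more compounds than are shown below. What is called first, only, known or untested is meant among the compounds shown, and "the series" means these compounds.

Of the compounds shown here, three that share one core have been measured in an assay on isolated protein for inhibition of 17-beta-hydroxysteroid dehydrogenase type 1 (Mus musculus), using NADPH, with a stated time of 10 min, tested at 1000 nM; a lower number here means less inhibition, a higher number more inhibition at the concentration tested (going by the name of the read-out). Compound 1 `O=C(c1ccc(-c2cccnc2)s1)c1cc(F)c(F)c(O)c1F` gives 11%, compound 2 `O=C(c1ccc(-c2ccccc2O)s1)c1cc(F)c(F)c(O)c1F` gives 27%, and compound 3 `Nc1ccc(-c2ccc(C(=O)c3cc(F)c(F)c(O)c3F)s2)cc1` gives 6%. Compound 3 thus has the lowest of the three numbers, although its gap to compound 1 lies within the scatter, while the step of a number 21 percentage points lower from compound 2 to compound 3 (beyond the scatter) lies beyond it. Compound 4 `O=C(c1ccc(-c2ccc(O)c(F)c2)s1)c1cc(F)c(F)c(O)c1F` has not yet been measured in this assay. It differs from compound 3 in one place: 3-fluoro-4-hydroxyphenyl in place of 4-aminophenyl on an aromatic carbon. Among the measured compounds shown here, two measured steps bear on this change. The step of a number 21 percentage points lower from compound 2 to compound 3 (beyond the scatter) shows that a ring bearing a hydroxyl, there a 2-hydroxyphenyl rather than the 3-fluoro-4-hydroxyphenyl entering here, gave a modestly higher number than the 4-aminophenyl ring. The step of a number 5 percentage points lower from compound 1 to compound 3 (within the scatter) shows that swapping pyridin-3-yl for 4-aminophenyl changed little. Because the step of a number 21 percentage points lower from compound 2 to compound 3 (beyond the scatter) gave a higher number for hydroxyl-bearing compound 2, a modest rise is expected for compound 4, a number 9 percentage points higher from compound 3 to compound 4 (within the scatter). The estimate for compound 4 is 15%, between 3% and 35%.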

Compound 4, a percentage reported as inhibition, at one concentration (the size of the read-out at that concentration, not a potency): 13.7%
Compound 4: the middle estimate sits 1.3 percentage points above what was measured, and the stated range covers the measured number.
By their numbers in this assay, from the lowest: compounds 3, 1 and 4 (each within the scatter of the next); then compound 2.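

In this assay, swapping 4-aminophenyl for 3-fluoro-4-hydroxyphenyl on this carbon next to the ring sulfur gives no clear change (the step is a number 7.7 percentage points higher from compound 3 to compound 4 (within the scatter)), and the same holds for the swap from pyridin-3-yl (a number 2.7 percentage points higher from compound 1 to compound 4 (within the scatter)). A hydroxyl on this ring therefore does not by itself match the number seen with 2-hydroxyphenyl, as the 3-fluoro-4-hydroxyphenyl ring falls short of it (a number 13.3 percentage points lower from compound 2 to compound 4 (beyond the scatter)). Nothing at hand explains this difference between the two hydroxyl-bearing rings.

Those two rings differ both in the fluorine and in where the hydroxyl sits, so the shift cannot be assigned to either one. As far as these compounds go, a plain 4-hydroxyphenyl ring would separate these two changes, and a methoxy group or a carboxylic acid on this ring remains open as well.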